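This account rests on a few compounds, and the source may have more. Where it says the series, first, only, none or still open, it means among the compounds named here.

In a functional assay on SW-620 cells (Homo sapiens) (a higher number here means a weaker inhibitor of growth, a lower number a stronger inhibitor of growth), compound 1 `O=S(=O)(/C=C/c1ccc(F)cc1F)Cc1ccc(Nc2ncnc3ccccc23)cc1` gives 86000 nM. Compound 2 `O=S(=O)(/C=C/c1ccc(Cl)cc1Cl)Cc1ccc(Nc2ncnc3ccc(Br)cc23)cc1` gives > 100000 nM, which is a limit of the assay and not a number. Compound 3 `O=S(=O)(/C=C/c1ccc(F)cc1F)Cc1ccc(Nc2ncnc3ccc(Br)cc23)cc1` differs from compound 2 in one place: 2,4-difluorophenyl in place of 2,4-dichlorophenyl on a double-bonded chain carbon bound to a double-bonded chain carbon. For the measured compounds named here, no measured pair shows the effect of this swap. A modest move towards stronger growth inhibition in this assay is expected, since compound 1, which also carries 2,4-difluorophenyl, gives 86000 nM. The expected change is an at least 1.3-fold lower number from compound 2 to compound 3 (0.12 log units; that floor lies within the scatter). The estimated value for compound 3 is 75000 nM, with an expected range of 30000 nM to 100000 nM.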

Compound 3, concentration for 50% growth inhibition: 100000 nM
The estimate for compound 3 lay 1.3-fold (0.12 log units) below the measured number; the range from low to high includes it.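

In this assay, bromo in place of hydrogen on an aromatic carbon, with 2,4-difluorophenyl kept, gives a 1.2-fold higher number from compound 1 to compound 3 (0.07 log units; within the scatter) and so shows no real change on the shared core. Compound 2 stands at a limit of the assay and not at a number. The swap from 2,4-dichlorophenyl to 2,4-difluorophenyl gives a number no higher from compound 2 to compound 3 (the limit leaves the size open) and its size cannot be read, because of this: the limit of > 100000 nM in this assay, at which 1 of the 3 values shown sits.

The compounds shown leave open whether a phenyl ring carrying an amine or a carboxylic acid at this place would give a clearly lower number.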